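Hydroxypiperidine in place of the aminoethyl chain: clearance note

A few compounds are considered here, and "the series" means these few. Any claim that something is new, unique, unknown or untested is made for them only; others in the source may bear on it.

Compound 1, `NCCCOc1ccc([C@H]2CC[C@]3(CC2)OOC2(O3)C3CC4CC(C3)CC2C4)cc1` — in an ADME assay on microsomes from liver (Homo sapiens) for metabolic stability, read by LC-MS, tested at 1 uM (on this read-out lower numbers stand for slow clearance and higher numbers for fast clearance), a limit of the assay, < 7 mL.min-1.g-1.
Compound 2, `c1cc([C@H]2CC[C@]3(CC2)OOC2(O3)C3CC4CC(C3)CC2C4)ccc1OCCC1CCNCC1` — in this assay a limit of the assay, < 7 mL.min-1.g-1.

Compound 1 stands at the assay limit, as does compound 2, so the step that the two limits leave unreadable from compound 1 to compound 2 cannot be read; both values sit together in the limit of < 7 mL.min-1.g-1 in this assay, at which 2 of the 2 values shown sit. Compound 3, `OC1(COc2ccc([C@H]3CC[C@]4(CC3)OOC3(O4)C4CC5CC(C4)CC3C5)cc2)CCNCC1`, carries the change (4-hydroxypiperidin-4-yl in place of 2-aminoethyl on a saturated chain carbon bound to an oxygen on an aromatic ring). Among the compounds with values here, no measured step gives a size for such a change. Compound 3 is expected to stay at the limit, with an estimated 5 mL.min-1.g-1 and a range of 2 mL.min-1.g-1 to 12 mL.min-1.g-1. The step that the limit leaves unreadable from compound 1 to compound 3 is therefore expected to lie within the scatter.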

Compound 3, intrinsic clearance in microsomes: 16 mL.min-1.g-1
Beside the measured number, compound 3's estimate is 3.2-fold (0.51 log units) below it; the measured number lies above the stated range.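

In this assay, the change at this place, a saturated chain carbon bound to an oxygen on an aromatic ring, now has a readable direction: an at least 2.2-fold higher number from compound 1 to compound 3 (0.35 log units; beyond the scatter), and an at least 2.2-fold higher number from compound 2 to compound 3 (0.35 log units; beyond the scatter). The amine-bearing groups at this place therefore do not all stay at the limit, though the step between compound 1 and compound 2 cannot be read. Both readable steps give only a minimum size, since each starts from a limit: the limit of < 7 mL.min-1.g-1 in this assay, at which 2 of the 3 values shown sit.

As far as these compounds go, whether the hydroxyl or the shorter link to the piperidine ring goes with the higher number stays open. A plain piperidin-4-yl on that same carbon would separate the two.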